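Methoxy for Dichloro on a Weakly Active Sulfonamide

A few compounds are considered here, and "the series" means these few. Any claim that something is new, unique, unknown or untested is made for them only; others in the source may bear on it.

Compound 1 `O=S(=O)(Nc1ccc2oc(-c3ccccc3)nc2c1)c1ccc(Cl)c(Cl)c1` was tested in an assay on cells for inhibition of HSP60/HSP10 (Homo sapiens), with a stated time of 60 min; a higher number here means a weaker inhibitor, a lower number a stronger inhibitor. There compound 1 gives > 100000 nM, which is a limit of the assay and not a number. Compound 1 thus stands at the limit of > 100000 nM in this assay, at which 2 of the 3 values shown sit, so no more can be said of it than that it falls outside the measurable range. Compound 2 `Cc1cccc(S(=O)(=O)Nc2ccc(-c3nc4ccccc4o3)cc2)c1` gives > 100000 nM in this assay, again a limit. Among the compounds with values here, compound 3 `O=S(=O)(Nc1ccc(-c2nc3ccccc3o2)cc1)c1ccc(C(F)(F)F)cc1` gives 50000 nM in this assay, the only value among the three that is a number. No two of these compounds differ in a single place, so the data hold no measured step from which a direction could be read.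

Compound 4 `COc1cccc(S(=O)(=O)Nc2ccc3oc(-c4ccccc4)nc3c2)c1` is not yet measured. It differs from compound 1 in one place: 3-methoxyphenyl in place of 3,4-dichlorophenyl on a sulfonyl sulfur. Because compound 1 sits at the limit of > 100000 nM in this assay, at which 2 of the 3 values shown sit, the data give no footing for a direction, and the estimated step in this assay is a number no higher from compound 1 to compound 4 (the limit leaves the size open), which amounts to no expected movement beyond the scatter. Compound 4 is therefore expected to give 100000 nM in this assay, with a range from 30000 nM to 300000 nM, and a fair chance that only a limit is reported.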

Compound 4, half-maximal inhibitory concentration: > 100000 nM
Compound 4: only a limit was reported; the forecaster's own chance of this, stated with the estimate: 65%; the middle value lies on the limit itself.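

In this assay compound 4 gives > 100000 nM as a limit of the assay and not a number. Within the data shown here, compound 1 also stands at a limit, so no step between compound 1 and compound 4 can be read: (the limit of > 100000 nM in this assay, at which 3 of the 4 values shown sit). The compounds shown leave open whether 3-methoxyphenyl and 3,4-dichlorophenyl on the sulfonyl sulfur differ at all in inhibition.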